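The source may hold more compounds than are shown below. What is called first, only, known or untested is meant among the compounds shown, and "the series" means these compounds.

Measured in a functional assay on A549 cells (Homo sapiens) for cytotoxicity, read by MTT assay, with a stated time of 48 h; a higher number here means a weaker inhibitor, a lower number a stronger inhibitor:
compound 1 `C#CC1=CC[C@@]2(C)C(=C)CCC[C@]2(C)CC1`: 148000 nM
compound 2 `C=C1CCC[C@]2(C)CCC(c3cn(-c4cccc([N+](=O)[O-])c4)nn3)=CC[C@@]12C`: 24700 nM
compound 3 `C=C1CCC[C@]2(C)CCC(c3cn(CC(=O)Nc4ccc(C)cc4)nn3)=CC[C@@]12C`: 270000 nM

Compound 2 holds the lowest number of the three, clearly under both compound 1 and compound 3. Compound 4 `C=C1CCC[C@]2(C)CCC(c3cn(-c4ccc(Cl)cc4)nn3)=CC[C@@]12C` is still unmeasured in this assay. It carries 4-chlorophenyl in place of 3-nitrophenyl on an aromatic nitrogen. Among the measured compounds shown here, no measured pair differs in one place, so the size of this step is a judgement. For the measured compounds named here, compound 2, at 24700 nM, is the only measured compound with a phenyl ring on that nitrogen and serves as the anchor. A rise in the number, near the edge of the scatter, is expected. The expected change is a 2.0-fold higher number from compound 2 to compound 4 (0.31 log units; beyond the scatter). For compound 4 the estimate is 50000 nM, with an expected range of 18000 nM to 140000 nM.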

Compound 4, half-maximal inhibitory concentration: 20100 nM
Estimate against measurement, compound 4: 2.5-fold (0.40 log units) above; measured number inside the range.
By their numbers in this assay, from the lowest: compounds 4 and 2 (each within the scatter of the next); then compounds 1 and 3 (each within the scatter of the next).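

In this assay the exchange on the aromatic nitrogen gives a 1.2-fold lower number from compound 2 to compound 4 (0.09 log units; within the scatter), so 4-chlorophenyl and 3-nitrophenyl cannot be told apart at this position. In this pair, the 2 hydrogen-bond acceptors of 3-nitrophenyl are not required to keep the number. No measurement at hand explains this match.

Still open, going by these compounds, is whether an amine or a carboxylic acid on that phenyl ring would read alike. This pair changes both the substituent and its place on the ring, and 3-chlorophenyl would separate the two.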